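The compounds below may be only part of what the source reports. "The series", "measured", "known", "first", "only" and "open" are said of these compounds alone.

In a functional assay on MDA-MB-231 cells (Homo sapiens) for antiproliferative activity, with a stated time of 5 days (a lower number here means a stronger inhibitor, a higher number a weaker inhibitor), compound 1 `COc1ccc(-n2nc(-c3ccc4ccccc4c3)nc2N2C(=O)COC23C=CC(=O)C=C3)cc1` gives 60 nM. Within the data shown here, this is the lower of the two numbers available so far, and so the stronger result. Compound 2 `CC1CN(c2nc(-c3ccc4ccccc4c3)nn2-c2ccccc2)C2(C=CC(=O)C=C2)O1` gives 130 nM, a gap slightly beyond the usual scatter of repeated measurements. The next compound, compound 3 `O=C1C=CC2(C=C1)OCC(=O)N2c1nc(-c2ccc3ccccc3c2)nn1-c1ccc2ccccc2c1`, keeps the core of compound 1 but carries naphthalen-2-yl in place of 4-methoxyphenyl on an aromatic nitrogen. Among the measured compounds shown here, no measured pair shows this change on its own, so any expectation here is loose. A small move toward a higher number in this assay is expected, possibly no larger than the scatter. The estimated size of this change is a 1.7-fold higher number from compound 1 to compound 3 (0.22 log units; within the scatter). For compound 3 the expected value is 100 nM, with an estimated range of 30 nM to 350 nM.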

Compound 3, half-maximal inhibitory concentration: 50 nM
Compound 3: the middle estimate sits 2.0-fold (0.30 log units) above what was measured; the measured number falls inside the stated range.
By their numbers in this assay, from the lowest: compounds 3 and 1 (each within the scatter of the next); then compound 2.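

On the aromatic nitrogen of the five-membered aromatic ring, naphthalen-2-yl can take the place of 4-methoxyphenyl with a 1.2-fold lower number from compound 1 to compound 3 (0.08 log units; within the scatter) in this assay, so this read-out does not separate the two compounds. The entering group has two six-membered aromatic rings of carbon only and no hydrogen-bond acceptor, whereas the leaving group has one such ring and one acceptor, so for this pair neither that acceptor nor the smaller ring size is needed to keep the number at this level. The data available give no reason for this outcome.

As far as these compounds go, it remains open how a much smaller group, such as methyl, or a group carrying an amine or a carboxylic acid, would behave at this nitrogen. Whether the same swap would hold on the different core of compound 2 is also unanswered.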